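The compounds below may be only part of what the source reports. "The series", "measured", "known", "first", "only" and "open" are said of these compounds alone.

Measured so far:
compound 1 `COc1ccc(/C=N/NC(=O)c2cc([N+](=O)[O-])cc([N+](=O)[O-])c2)cc1` with 3.08
compound 2 `COc1ccc(/C=N/NC(=O)c2ccc([N+](=O)[O-])cc2)cc1` with 3.13
compound 3 `COc1ccc(/C=N/NC(=O)c2cc([N+](=O)[O-])cc([N+](=O)[O-])c2)cc1OC` with 2.83

Among the three, compound 3 has the lowest number in a physicochemical assay for lipophilicity (on this read-out lower numbers stand for lower lipophilicity and higher numbers for higher lipophilicity), but its neighbours sit close: the step of a number 0.25 log units lower from compound 1 to compound 3 (within the scatter) stays within the scatter, and compound 2 stands only slightly higher, also within the scatter. Nothing here separates the three compounds beyond the noise of this assay.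

Compound 4 `COc1ccc(/C=N/NC(=O)c2cccc([N+](=O)[O-])c2)cc1OC` is the next compound. It differs from compound 3 in one place: hydrogen in place of nitro on an aromatic carbon. Among the compounds with values here, no measured step follows this kind of change directly. Within the data shown here, the only measured step, from compound 1 to compound 3, concerns a methoxy entering and is therefore no guide. Compound 1 and compound 2 differ in nitro count among other things, and their two values lie within the scatter of each other, which at least gives no sign of a large effect from one nitro group fewer. He therefore expects at most a small step in this assay, with a slightly higher number somewhat more likely than a lower one, but nothing beyond the scatter. His estimate for compound 4 is 2.95, between 2.6 and 3.3, which means an expected step of a number 0.12 log units higher from compound 3 to compound 4 (within the scatter).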

Compound 4, partition coefficient: 2.87
Estimate against measurement, compound 4: 0.08 log units above; measured number inside the range.
By their numbers in this assay, from the lowest: compounds 3, 4, 1 and 2 (each within the scatter of the next).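

Replacing nitro with hydrogen on an aromatic carbon, meta to a large group and meta to a nitro group, gives a number 0.04 log units higher from compound 3 to compound 4 (within the scatter) in this assay. This is the first pair shown that isolates this change, whereas the earlier step concerned a methoxy entering, and the comparison of compound 1 with compound 2 involved more than one difference. In this pair, the departure of nitro, with its 3 heavy atoms and 2 hydrogen-bond acceptors, leaves the two compounds within the scatter, so the reading for this position on this core is direct, although it rests on a single pair and no measurement at hand accounts for it.

The compounds shown leave open whether the same exchange would read alike in the core of compound 1, with its single methoxy, or at the other nitro position, as this one step cannot speak for either case. They also leave open how this assay would respond to an amine or a carboxylic acid on this aromatic carbon, where only nitro and hydrogen appear so far.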